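Compound 4: Dihydroxyphenyl in Place of Trifluorophenyl

The compounds below may be only part of what the source reports. "The series", "measured", "known", "first", "only" and "open" are said of these compounds alone.

In a functional assay on HOS cells (Homo sapiens) for antiproliferative activity, with a stated time of 72 h (on this read-out lower numbers stand for stronger inhibition and higher numbers for weaker inhibition), compound 1 `OC[C@H]1O[C@@H](n2cnc3c(NCc4ccc(Cl)cc4)ncnc32)[C@H](O)[C@@H]1O` gives > 166000 nM, which is a limit of the assay and not a number. Compound 2 `COc1cccc(CNc2ncnc3c2ncn3[C@@H]2O[C@H](CO)[C@@H](O)[C@H]2O)c1` gives > 166000 nM, again a limit. The entry for compound 3 `OC[C@H]1O[C@@H](n2cnc3c(NCc4c(F)ccc(F)c4F)ncnc32)[C@H](O)[C@@H]1O` reads "not determined" (no result reported), so compound 3 has no number of its own and can only be viewed against its two relatives. The evidence around it is the limit of > 166000 nM in this assay, at which 2 of the 3 values shown sit.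

The change leads to compound 4 `OC[C@H]1O[C@@H](n2cnc3c(NCc4cccc(O)c4O)ncnc32)[C@H](O)[C@@H]1O`: 2,3-dihydroxyphenyl in place of 2,3,6-trifluorophenyl on a saturated chain carbon bound to a nitrogen on an aromatic ring. In words, this places 2,3-dihydroxyphenyl in place of 2,3,6-trifluorophenyl on a saturated chain carbon bound to a nitrogen on an aromatic ring.

Among the measured compounds shown here, the only measured step that bears on this is a step that the two limits leave unreadable from compound 1 to compound 2. It is also an exchange of the aryl group, but it offers no size to carry over, and with no starting value for compound 3 no step size or direction can be expected in this assay. Weak activity remains the expectation, and a report of only a limit is more likely than not. For compound 4 the estimated value is 80000 nM, with an expected range from 8000 nM to 166000 nM.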

Compound 4, half-maximal inhibitory concentration: > 166000 nM
Compound 4 ended at the assay's limit; the forecaster's own chance of this, stated with the estimate: 60%; middle value at least 2.0-fold (0.31 log units) from the limit.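

Compound 4 sits at a limit of this assay, as do compound 1 and compound 2, so neither the step from compound 2 to compound 4 nor the step from compound 1 to compound 4 can be read. The compounds shown leave open whether any of these aryl exchanges on the shared core changes activity in this assay, and where compound 3 stands: the limit of > 166000 nM in this assay, at which 3 of the 4 values shown sit.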